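A Bulkier Group, Then a Swap of the Aryl Ring

The source may hold more compounds than are shown below. What is called first, only, known or untested is meant among the compounds shown, and "the series" means these compounds.

Of the compounds shown here, three built on one shared core have been measured in a functional assay on the whole organism (strain Swiss albino) for inhibition, with Mus musculus as the target, in the writhing test, with a stated time of 30 min, at a dose of 100 mg/kg; a higher number here means more inhibition at the dose given (going by the name of the read-out), a lower number less inhibition. Compound 1 `CCN1CCc2c(c(C)nn2C(=O)Nc2ccc(Br)cc2)C1` gives 59.7%. Compound 2 `CCN1CCc2c(c(C)nn2C(=O)Nc2c(C)cccc2C)C1` gives 60.5%; its number and that of compound 1 lie within the usual scatter of each other, so no order between the two can be read. Compound 3 `CCN1CCc2c(c(C(C)(C)C)nn2C(=O)Nc2ccc(Br)cc2)C1` gives 72.8%, the highest of the three numbers, beyond the scatter from both compound 2 and compound 1. Within the data shown here, the only single change with a measured step runs a number 13.1 percentage points higher from compound 1 to compound 3 (beyond the scatter), so tert-butyl in place of methyl on an aromatic carbon raised the read-out.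

Compound 4 `CCN1CCc2c(c(C(C)(C)C)nn2C(=O)Nc2cc(C)ccc2C)C1` keeps the tert-butyl of compound 3 and changes the other end: 2,5-dimethylphenyl in place of 4-bromophenyl on an amide-type nitrogen. Among the measured compounds shown here, no measured step covers this exact exchange. The closest hint comes from compound 1 and compound 2, which differ only in the ring on the amide-type nitrogen and whose numbers lie within the scatter of each other. On that basis the exchange is expected to leave the number roughly where compound 3 stands. Compound 4 is expected to show a number 2.8 percentage points lower from compound 3 to compound 4 (within the scatter). Compound 4 is therefore estimated at 70%, in a range from 58% to 82%.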

Compound 4, a percentage reported as inhibition, in the whole organism at one dose (the size of the read-out at that dose, not a potency): 63.1%
Compound 4: the middle estimate sits 6.9 percentage points above what was measured; the measured number falls inside the stated range.
By their numbers in this assay, from the lowest: compounds 1, 2, 4 and 3 (each within the scatter of the next, the first and the last beyond it).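

In this assay, 2,5-dimethylphenyl in place of 4-bromophenyl on an amide-type nitrogen gives a number 9.7 percentage points lower from compound 3 to compound 4 (within the scatter), so no order between these two compounds can be read. Among these compounds, this is the first measured exchange of this ring with the tert-butyl group present on the shared core, and it shows that the 2,5-dimethylphenyl ring keeps the read-out within the usual scatter of the 4-bromophenyl ring. The step is still sizeable for one inside the scatter, so it does not prove that the two rings behave alike, and no measurement at hand explains the result or says what either ring does at this position.

The compounds shown leave open how an unsubstituted phenyl ring, or a ring carrying a methoxy group or a carboxylic acid, would fare on the amide-type nitrogen with tert-butyl kept in place. They also leave open whether an isopropyl group, a cyclohexyl ring or a longer chain on the aromatic carbon would match tert-butyl, and whether replacing the ethyl group on the ring nitrogen of the shared core with a benzyl group would shift the read-out.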